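A few compounds are considered here, and "the series" means these few. Any claim that something is new, unique, unknown or untested is made for them only; others in the source may bear on it.

Working notes on a small set of anilides carrying a sulfonamide.

Compound 1 `CCS(=O)(=O)Nc1ccc(NC(=O)c2ccc(Cl)cc2)cc1C` in an ADME assay on RAW264.7 cells (Mus musculus) for cytotoxicity, read by MTT assay, with a stated time of 48 h (on this read-out higher numbers stand for weaker inhibition and lower numbers for stronger inhibition), gives 68700 nM. Compound 3 `Cc1cc(NC(=O)c2ccc(Cl)cc2)ccc1NS(=O)(=O)C(F)(F)F` is the matched partner of compound 1 and differs from it by one change: trifluoromethyl in place of ethyl on a sulfonyl sulfur. That change gave a 1.9-fold lower number from compound 1 to compound 3 (0.29 log units; within the scatter).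

Compound 2 `CCS(=O)(=O)Nc1ccc(NC(=O)c2cccc(C(F)(F)F)c2)cc1C` gives 114000 nM. The difference between the core of compound 2 and the core of compound 1 is not broken down here. Compound 2 and compound 1 sit within the usual scatter of each other, while compound 3, with 35400 nM, lies beyond the scatter from compound 2.

Compound 4 `Cc1cc(NC(=O)c2cccc(C(F)(F)F)c2)ccc1NS(=O)(=O)C(F)(F)F` is not yet measured. It differs from compound 2 by trifluoromethyl in place of ethyl on a sulfonyl sulfur. The place of the change reads the same for both pairs, so this is the same change as from compound 1 to compound 3, seen for the second time in the set. Among the compounds with values here, the step from compound 2 to compound 4 is expected to be of similar size, a 1.8-fold lower number from compound 2 to compound 4 (0.26 log units; within the scatter), because the one measured precedent is a 1.9-fold lower number from compound 1 to compound 3 (0.29 log units; within the scatter) and it lies within the scatter. On that basis compound 4 is estimated at 62000 nM, with a plausible range from 30000 nM to 125000 nM.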

Compound 4, half-maximal inhibitory concentration: 8720 nM
Compound 4: middle estimate off by 7.1-fold (0.85 log units), on the high side; the whole stated range lies above it.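

Trifluoromethyl in place of ethyl on a sulfonyl sulfur gives a 13-fold lower number from compound 2 to compound 4 (1.12 log units; beyond the scatter) in this assay. The size of this change is therefore not constant across the two cores shown, and the step on one core cannot simply be carried over to the other: the same change on two cores in this assay, a 1.9-fold lower number (0.29 log units; within the scatter) from compound 1 to compound 3 and a 13-fold lower number (1.12 log units; beyond the scatter) from compound 2 to compound 4, 6.7-fold (0.83 log units) apart, beyond the scatter of two such steps

This does not show which feature of the cores sets the size of the step, since the difference between them is not broken down, and a single comparison of two cores gives no rule for any other core in the series.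

The compounds shown leave open whether a step as large as the one on the core of compound 2 would recur on further cores or remains confined to that core. They also leave open how a longer chain or an amine on the sulfonyl sulfur, in place of ethyl or trifluoromethyl, would read in this assay.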